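From Methoxy to Chloro: One Swap on a Shared Core

The source may hold more compounds than are shown below. What is called first, only, known or untested is meant among the compounds shown, and "the series" means these compounds.

Of the compounds shown here, three built on the same core have been measured in a physicochemical assay for lipophilicity, read by HPLC, at pH 7.5; a lower number here means a more polar compound, a higher number a more lipophilic compound. Compound 1 `CC[C@@H](Nc1c(C#N)c(-c2ccc(-c3ccc(OC)cc3)cc2)nc2cnccc12)C(N)=O` gives 2.7. Compound 2 `CCOc1ccccc1-c1ccc(-c2nc(NC(C)C(=O)O)c3ccncc3n2)cc1`, in this assay, gives 2.1, and compound 3 `CC[C@@H](Nc1c(C#N)c(-c2ccc(-c3cccc(Cl)c3F)cc2)nc2cnccc12)C(=O)O` gives 2.2. Compound 1 therefore stands highest of the three, and the distances from it to compound 3 and to compound 2 both lie beyond the usual scatter of repeated measurements.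

Compound 4 `CC[C@@H](Nc1c(C#N)c(-c2ccc(-c3ccc(Cl)cc3)cc2)nc2cnccc12)C(N)=O` has not yet been measured. It is compound 1 with a single change: chloro in place of methoxy on an aromatic carbon. Among the measured compounds shown here, no pair of measured compounds shows this particular swap, so there is no directly measured step to lean on, and the expectation must rest on the position of compound 1 alone together with the nature of the change.

The step of a number 0.60 log units higher from compound 1 to compound 4 (beyond the scatter) is expected to point upward, by more than the scatter. For compound 4, the estimated value in this assay is 3.3, with a range from 2.9 to 3.8 within which most repeated measurements of this kind should fall. The measured number will show whether compound 4 indeed moves above compound 1.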

Compound 4, distribution coefficient: 3.1
Compound 4: the middle estimate sits 0.20 log units above what was measured, within the range that was stated.
By their numbers in this assay, from the lowest: compounds 2 and 3 (each within the scatter of the next); then compound 1; then compound 4.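

In this assay, among the compounds shown here, putting chloro in place of methoxy on an aromatic carbon, para to a large group, gives a number 0.40 log units higher from compound 1 to compound 4 (beyond the scatter), and this is the first measured step here in which only one place on the shared core changes. It shows that this position is not indifferent to the swap: with the rest of compound 1 held fixed, a group of 2 heavy atoms with 1 hydrogen-bond acceptor leaves, one of 1 heavy atom with no hydrogen-bond acceptor enters, and the number moves upward by more than repeat measurements would normally scatter. Nothing measured on these compounds accounts for the rise, so this single pair records its direction and size but not its origin.

The compounds shown leave open how other groups on this same carbon would read, such as trifluoromethyl, a primary amine or a longer chain like butoxy. They also leave open whether the same swap would give a step of similar size on a compound carrying a carboxylic acid, as compound 3 does, in place of the amide of compound 1.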